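Adding a Methyl to a Saturated Ring

A few compounds are considered here, and "the series" means these few. Any claim that something is new, unique, unknown or untested is made for them only; others in the source may bear on it.

Three compounds with a shared core were tested in an ADME assay on HepG2 cells (Homo sapiens) for cytotoxicity, read by CellTiter-Glo and ATP content, with a stated time of 72 h; a higher number here means that more compound is needed for the effect, a lower number that less compound is needed. Compound 1, `CS(=O)(=O)c1ccc(C(=O)N2CCC(C(=O)N3CCN(c4ccc(F)cc4)CC3)CC2)cc1[N+](=O)[O-]`, reaches only the limit of the assay, reported as > 27000 nM. Compound 2, `CS(=O)(=O)c1ccc(C(=O)NCCC(=O)N2CCCCC2)cc1[N+](=O)[O-]`, likewise gives no number but the limit > 27000 nM. Compound 3, `CS(=O)(=O)c1ccc(C(=O)NCC(=O)N2CCN(c3ccccc3F)CC2)cc1[N+](=O)[O-]`, also stops at the limit, > 27000 nM. Compound 2 therefore stands exactly where every measured compound stands, at the ceiling of this assay with no number beneath it, as the limit of > 27000 nM in this assay, at which 3 of the 3 values shown sit, shows.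

Compound 4, `CC1CCN(C(=O)CCNC(=O)c2ccc(S(C)(=O)=O)c([N+](=O)[O-])c2)CC1`, differs from compound 2 in one place: methyl in place of hydrogen on a saturated ring carbon. Within the data shown here, no pair of measured compounds differs in a single place, so no measured step is available to size this change. The expectation for compound 4 in this assay is no step beyond the usual scatter, in either direction. Compound 4 is accordingly expected to give about 40000 nM, within a range from 15000 nM to 100000 nM. The implied step, a step that the limit leaves unreadable from compound 2 to compound 4, is expected to be essentially nil, and this assay will most likely once more report only its limit.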

Compound 4, half-maximal effective concentration: > 27000 nM
Compound 4: only a limit was reported; the forecaster's own chance of this, stated with the estimate: 85%; the middle value is on the limit's open side.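

In this assay, compound 2 and compound 4 each give only a limit and not a number, so no step between them can be read: the limit of > 27000 nM in this assay, at which 4 of the 4 values shown sit.

The compounds shown leave open whether methyl in place of hydrogen on a saturated ring carbon changes the concentration needed for the effect at all.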